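Swapping 4-chlorophenyl for naphthalen-1-yl on compound 1

This account rests on a few compounds, and the source may have more. Where it says the series, first, only, none or still open, it means among the compounds named here.

In an ADME assay on cells (Macrophage) for cytotoxicity, read by resazurin assay, with a stated time of 48 h (on this read-out higher numbers stand for lower toxicity in this test and lower numbers for higher toxicity in this test), compound 1 `Nc1nc(-c2ccc(Cl)cc2)cc(-c2ccc(OCc3cn(Cc4ccccc4)nn3)cc2O)n1` gives 66600 nM and compound 2 `O=C1CC(c2ccc(Br)cc2)Oc2cc(OCc3cn(Cc4ccc(Br)cc4)nn3)ccc21` gives 87500 nM, two numbers that lie within the scatter of each other. For the measured compounds named here, these are the only two numbers available, so compound 1 stands level with compound 2 and no order can be drawn between them. Compound 3 `O=C1CC(c2ccc(Cl)cc2)Oc2cc(OCc3cn(Cc4ccccc4)nn3)ccc21` adds no comparison, since its entry in this assay reads "not determined" (no result reported) and carries no number.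

Compound 4 `Nc1nc(-c2ccc(OCc3cn(Cc4ccccc4)nn3)cc2O)cc(-c2cccc3ccccc23)n1` has naphthalen-1-yl in place of 4-chlorophenyl on an aromatic carbon of the shared core. Going by the values given here, no two measured compounds differ in one place only, so this change has no direct precedent. The expectation therefore starts from compound 1 at 66600 nM and allows a wide margin. The expected step of a 1.2-fold lower number from compound 1 to compound 4 (0.08 log units; within the scatter) is none beyond the scatter, with no direction that can be called. Compound 4 is estimated at 55000 nM, with an expected range from 22000 nM to 110000 nM in this assay.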

Compound 4, half-maximal cytotoxic concentration: 71300 nM
The estimate for compound 4 lay 1.3-fold (0.11 log units) below the measured number; the measured number falls inside the stated range.
By their numbers in this assay, from the lowest: compounds 1, 4 and 2 (each within the scatter of the next).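

In this assay, for the compounds shown here, naphthalen-1-yl in place of 4-chlorophenyl on an aromatic carbon of the shared core gives a 1.1-fold higher number from compound 1 to compound 4 (0.03 log units; within the scatter), the first comparison in this set in which only one place differs. This position, next to the ring nitrogen, therefore takes a group of 10 heavy atoms with 2 six-membered aromatic rings instead of one of 7 heavy atoms with a single ring, and the two compounds still stand level on this read-out. Nothing measured here offers an explanation for that.

Both groups compared are aromatic, with no hydrogen-bond donors or acceptors and no net charge. The compounds shown therefore leave open whether an amine, a carboxylic acid or a longer alkyl chain at this place would also stay within the scatter of compound 1.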